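The source may report more compounds than this note shows. Statements on the series, on what has been measured and on what is new or still open speak of the compounds shown alone.

Measured so far:
Compound 1, `Cc1cc(C)n(-c2cc(=O)cc(-c3ccccc3)[nH]2)n1`. In an ADME assay on CHO cells (Cricetulus griseus) for cytotoxicity, read by MTT assay (a lower number here means a stronger inhibitor, a higher number a weaker inhibitor), compound 1 is reported only as a limit, > 50000 nM.
Compound 2, `Cc1cc(C)n(-c2nc(C(F)(F)F)cc(=O)[nH]2)n1`. In this assay compound 2 gives 150000 nM.
Compound 3, `Cc1cc(C)n(-c2nc(-c3ccc(F)cc3)c(C(=O)O)c(=O)[nH]2)n1`. In this assay compound 3 is reported only as a limit, > 50000 nM.

Compound 2 is the only one of the three with a number; the other two values are limits, sitting at the limit of > 50000 nM in this assay, at which 2 of the 3 values shown sit. Among the compounds with values here, because of the limit of > 50000 nM in this assay, at which 2 of the 3 values shown sit, no step between measured compounds can be drawn, and nothing in the set says how a change on the five-membered ring moves the read-out.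

Compound 4, `Cc1cc(NC2CCOCC2)n(-c2nc(C(F)(F)F)cc(=O)[nH]2)n1`, is not yet measured. It differs from compound 2 by (oxan-4-yl)amino in place of methyl on an aromatic carbon. Within the data shown here, with no measured step as a guide, the expectation is that the step from compound 2 to compound 4 in this assay, a 1.3-fold lower number from compound 2 to compound 4 (0.10 log units; within the scatter), stays within the scatter, with no clear direction. Compound 4 is therefore estimated at 120000 nM, with a range from 40000 nM to 300000 nM. A reported limit instead of a number is also a real possibility for compound 4.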

Compound 4, half-maximal inhibitory concentration in the CHO assay: 18000 nM
Beside the measured number, compound 4's estimate is 6.7-fold (0.82 log units) above it, outside the stated range (below it).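

Within the data shown here, in the CHO assay, this is the first readable step, and it shows that the aromatic carbon next to the ring nitrogen is a place where a change moves the read-out beyond the scatter: an 8.3-fold lower number from compound 2 to compound 4 (0.92 log units; beyond the scatter). With (oxan-4-yl)amino in place of methyl, the number falls, so compound 4 is the stronger inhibitor of this pair. In a physicochemical assay for solubility, read by HPLC, measured as kinetic solubility, with a stated time of 20 h, at pH 7.4, tested at 200 uM (a higher number here means a more soluble compound, a lower number a less soluble compound), compound 2 gives 200000 nM and compound 4 gives 50000 nM, and compound 4 is also the less soluble of the pair: the measured solubility of compound 2, 200000 nM, and of compound 4, 50000 nM, a 4.0-fold lower number (0.60 log units; beyond the scatter)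

With a single replacement at this carbon, the compounds shown do not separate the part played by the linking nitrogen from that of the oxan-4-yl ring, which a plain amine or a cyclohexylamino group would address. Steps to compound 1 and compound 3 cannot be read, so any comparison with them stays open: the limit of > 50000 nM in the CHO assay, at which 2 of the 4 values shown sit.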